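A few compounds are considered here, and "the series" means these few. Any claim that something is new, unique, unknown or untested is made for them only; others in the source may bear on it.

Of the compounds shown here, two sharing one core have been measured so far. In a functional assay on SH-SY5Y cells (Homo sapiens) for antagonist activity, read by cAMP accumulation (on this read-out higher numbers stand for higher potency (the scale is a negative logarithm) and lower numbers for lower potency), compound 1 (`FC(F)(F)COc1ccc(Cc2ccc(NC3=NCCN3)cc2)cc1`) gives 8.7, and compound 2 (`OCCOc1ccc(Cc2ccc(NC3=NCCN3)cc2)cc1`) gives 8, the lower of the two numbers. Compound 3 (`COCCOc1ccc(Cc2ccc(NC3=NCCN3)cc2)cc1`) has not yet been measured. It differs from compound 2 by methyl in place of hydrogen on an oxygen on a saturated carbon, with methyl in place of hydrogen on an oxygen on a saturated carbon, turning 2-hydroxyethyl into 2-methoxyethyl. Among the measured compounds shown here, no measured step makes this exact change. For the measured compounds named here, the only guide is the step of a number 0.70 log units lower from compound 1 to compound 2 (beyond the scatter), which replaced trifluoromethyl with hydroxymethyl on the same side chain. Like compound 1, at 8.7, compound 3 carries no hydroxy group, so a small upward move in this assay is expected, smaller than that measured step. The estimated step is a number 0.30 log units higher from compound 2 to compound 3 (within the scatter). For compound 3 the estimate is 8.3, with an expected range of 7.9 to 8.7.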

Compound 3, negative logarithm of the antagonist equilibrium constant: 8
For compound 3 the middle estimate is 0.30 log units above the measured one; low and high end bracket the measured number.
By their numbers in this assay, from the lowest: compounds 2 and 3 (each within the scatter of the next); then compound 1.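

In this assay, turning 2-hydroxyethyl into 2-methoxyethyl gives no change at the digits printed from compound 2 to compound 3 (within the scatter), so methyl in place of hydrogen on this oxygen leaves no readable difference. Putting methoxymethyl in place of trifluoromethyl gives a number 0.70 log units lower from compound 1 to compound 3 (beyond the scatter), the same size as a number 0.70 log units lower from compound 1 to compound 2 (beyond the scatter), which shows that the gap to compound 1 remains once the hydroxy hydrogen is gone, so that hydrogen alone does not separate compound 2 from compound 1. No supporting evidence is available to explain these numbers.

Going by these compounds, whether an amine or a carboxylic acid in place of the methoxy group would fall with compounds 2 and 3 or with compound 1 remains open. So does the outcome for a longer chain carrying the same methoxy group.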